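The source may hold more compounds than are shown below. What is called first, only, known or untested is meant among the compounds shown, and "the series" means these compounds.

Measured in a functional assay on MCF7 cells (Homo sapiens) for inhibition, read by sulforhodamine B assay, with a stated time of 48 h; on this read-out higher numbers stand for weaker inhibition of growth and lower numbers for stronger inhibition of growth:
- compound 1 `COc1ccc(/C=C/C2(C)C=CC(=O)O2)cc1OC`: 78900 nM
- compound 2 `COc1cc(OC)c(OC)cc1/C=C/C1(C)C=CC(=O)O1`: 144000 nM

Compound 1 and compound 2 lie within the scatter of each other, so compound 1 has no separate standing on these two numbers. Compound 3 `COc1cccc(/C=C/C2(C)C=CC(=O)O2)c1` keeps the core of compound 1 and carries hydrogen in place of methoxy on an aromatic carbon. Among the measured compounds shown here, the only measured step that bears on this is a 1.8-fold higher number from compound 1 to compound 2 (0.26 log units; within the scatter). There a methoxy replaces hydrogen on a different aromatic carbon, the reverse kind of change, so it is only indirect evidence. No step beyond the scatter is therefore expected in this assay, and no direction can be assigned. The estimated step is a 1.1-fold higher number from compound 1 to compound 3 (0.03 log units; within the scatter). Compound 3 is expected at 85000 nM, with an estimated range from 35000 nM to 190000 nM.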

Compound 3, concentration for total growth inhibition: 25300 nM
Compound 3: middle estimate off by 3.4-fold (0.53 log units), on the high side; measured number below the stated range.
By their numbers in this assay, from the lowest: compound 3; then compounds 1 and 2 (each within the scatter of the next).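

In this assay hydrogen in place of the methoxy that is para to a group of 9 heavy atoms gives a 3.1-fold lower number from compound 1 to compound 3 (0.49 log units; beyond the scatter) and so moves the number toward stronger inhibition of growth. Among the compounds shown here, this is the first step beyond the scatter, though only a modest one, while the methoxy added on a different aromatic carbon gave a 1.8-fold higher number from compound 1 to compound 2 (0.26 log units; within the scatter) and stayed within it. The ring substituents of the core of compound 1 are therefore not all interchangeable on this read-out, and no data on hand explain the shift.

As far as these compounds go, whether a hydroxyl, a fluorine or an amine on this carbon would match hydrogen or methoxy remains open. Also open, from the compounds shown here alone, is whether the remaining methoxy of compound 3 contributes at all, as a compound with hydrogen in its place would show.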